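The source may report more compounds than this note shows. Statements on the series, on what has been measured and on what is new or still open speak of the compounds shown alone.

Compound 1 `Nc1nc(N)c2c(-c3ccsc3)cn([C@@H]3O[C@H](CO)[C@@H](O)[C@H]3O)c2n1`: > 20000 nM
Compound 2 `O=c1[nH]cnc2c1c(-c1ccoc1)cn2[C@@H]1O[C@H](CO)[C@@H](O)[C@H]1O`: > 20000 nM
Compound 3 `Cc1ncnc2c1c(I)cn2[C@@H]1O[C@H](CO)[C@@H](O)[C@H]1O`: 4080 nM

Of the compounds shown here, three have been measured in a functional assay on HeLa S3 cells (Homo sapiens) for antiproliferative activity, read by XTT assay, with a stated time of 72 h; a lower number here means a stronger inhibitor, a higher number a weaker inhibitor. Compound 2 gives > 20000 nM, which is a limit of the assay and not a number. Compound 1 likewise sits at a limit. Compound 3 is the only one of the three with a numerical value, giving 4080 nM in this assay. Compound 2 therefore stands at the weak end of what has been seen, at the limit of > 20000 nM in this assay, at which 2 of the 3 values shown sit.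

Compound 4 `O=c1[nH]cnc2c1c(-c1cccs1)cn2[C@@H]1O[C@H](CO)[C@@H](O)[C@H]1O` is not yet measured. It differs from compound 2 in one place: thiophen-2-yl in place of furan-3-yl on an aromatic carbon. For the measured compounds named here, no step between two measured compounds covers this change, so its size and direction are not known from the data. Compound 1 carries a related five-membered ring and also sits at the limit, while compound 3 carries no such ring and gives a number. On this basis the step from compound 2 to compound 4 is expected to be small, with no clear direction beyond the scatter, and compound 4 is expected to remain at or near the limit. The expected step is a number no higher from compound 2 to compound 4 (the limit leaves the size open). Compound 4 is thus estimated at 20000 nM, with a range from 7000 nM to 60000 nM in this assay.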

Compound 4, half-maximal inhibitory concentration: > 20000 nM
Compound 4 ended at the assay's limit (the forecaster's own chance of this, stated with the estimate: 70%); the middle value sits exactly at the limit.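

Compound 2 and compound 4 both sit at the limit of this assay, so no step can be read for thiophen-2-yl in place of furan-3-yl. The compounds shown leave open whether furan-3-yl and thiophen-2-yl differ at all in this assay, and whether either group on this core could give a numerical value.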